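Epimer of a bicyclic prostaglandin analogue at the ring carbon

The compounds below may be only part of what the source reports. "The series", "measured", "known", "first", "only" and "open" are said of these compounds alone.

Two bicyclic analogues were examined in a functional assay on CHO cells for agonist activity at prostaglandin F2-alpha receptor (Homo sapiens), read by fluorescence and calcium flux; on this read-out higher numbers stand for an effect only at larger amounts of compound and lower numbers for an effect already at smaller amounts. Compound 1, `O=C(O)CC[C@H]1CC[C@@H]2[C@@H](/C=C/[C@@H](O)COc3ccccc3)[C@H](O)C[C@@H]2OC1`, gives 110 nM in this assay. Compound 2, `O=C(O)CC[C@@H]1CCC[C@@H]2[C@@H](/C=C/[C@@H](O)COc3ccccc3)[C@H](O)C[C@@H]2O1`, gives 3.8 nM in this assay, the lowest of the two numbers; compound 1 stands apart from it by a gap beyond the scatter. Compound 3, `O=C(O)CC[C@H]1CCC[C@@H]2[C@@H](/C=C/[C@@H](O)COc3ccccc3)[C@H](O)C[C@@H]2O1`, has not yet been measured in this assay. Compound 3 differs from compound 2 in only one respect: the two compounds have the same atoms and bonds and differ only in configuration as drawn: 1 of 7 stereo elements differ; a stereocentre at a saturated ring carbon is drawn S in compound 2 and R in compound 3. No comparison between two measured compounds isolates such a change in configuration at the ring carbon. Among the compounds with values here, no measured step can guide the expectation directly, and the estimate rests on compound 2 alone. The step from compound 2 to compound 3 is expected to move toward a higher number, beyond the scatter, as an 11-fold higher number from compound 2 to compound 3 (1.02 log units; beyond the scatter). Compound 3 is therefore estimated at 40 nM in this assay, within a range from 8 nM to 300 nM.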

Compound 3, half-maximal effective concentration: 22 nM
The estimate for compound 3 lay 1.8-fold (0.26 log units) above the measured number, within the range that was stated.
By their numbers in this assay, from the lowest: compound 2; then compound 3; then compound 1.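

In this assay, inverting the stereocentre at the saturated ring carbon gives a 5.8-fold higher number from compound 2 to compound 3 (0.76 log units; beyond the scatter), and this is the only pair shown that isolates a change at this position. The drawn configuration at this carbon therefore changes the read-out by itself, with the S form in compound 2 giving the lower number, while the R form in compound 3 still gives a defined value of 22 nM. The gap can be assigned to this one centre because nothing else separates the two structures: the fact that compounds 2 and 3 differ only in the configuration as drawn

The compounds shown leave open whether the same preference for the S form would hold with a methyl ester or an amide in place of the carboxylic acid. They also do not tell whether a chlorine on the phenyl ring would alter the size of this step.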